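This account rests on a few compounds, and the source may have more. Where it says the series, first, only, none or still open, it means among the compounds named here.

Measured so far in an assay on PC-12 cells for displacement of a labelled ligand from vesicular acetylcholine transporter (Homo sapiens); on this read-out lower numbers stand for stronger inhibition and higher numbers for weaker inhibition:
- compound 1, `OC1CN(Cc2ccccc2)CCC1N1CCN(c2ccccc2)CC1`: 57 nM
- compound 2, `OC1CN(Cc2cccc(Br)c2)CCC1N1CCN(c2ccccc2)CC1`: 66 nM

Compound 2 stands alongside compound 1 on these two numbers: the step of a 1.2-fold higher number from compound 1 to compound 2 (0.06 log units; within the scatter) stays within the scatter, so the two compounds are not separated by this assay.

Compound 3, `CCN1CCC(N2CCN(c3ccccc3)CC2)C(O)C1`, is not yet measured. Its difference from compound 2: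
methyl in place of 3-bromophenyl on a saturated chain carbon bound to an amine nitrogen in a ring

For the measured compounds named here, only one measured step exists, and it bears on this change just loosely: it swaps bromo for hydrogen on the aromatic ring that now leaves altogether, and it moved the number within the scatter. Going by the values given here, no measured pair shows what removing the 3-bromobenzyl itself does, so the expectation for compound 3 rests on a wide range rather than on a matched step.

Compound 3 is expected to give 600 nM in this assay, within 100 nM to 4000 nM, which means an expected step of a 9.1-fold higher number from compound 2 to compound 3 (0.96 log units; beyond the scatter).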

Compound 3, half-maximal inhibitory concentration: > 1000 nM
Compound 3 was reported as a limit; the forecaster's own chance of this, stated with the estimate: 5%; middle value at least 1.6-fold (0.22 log units) from the limit.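

Methyl in place of 3-bromophenyl on a saturated chain carbon bound to an amine nitrogen in a ring gives an at least 15-fold higher number from compound 2 to compound 3 (1.18 log units; beyond the scatter) and methyl in place of phenyl at the same place gives an at least 17-fold higher number from compound 1 to compound 3 (1.24 log units; beyond the scatter), both large and beyond the scatter. This place is therefore not indifferent to what it carries: bromo on the aromatic ring left the number within the scatter in a 1.2-fold higher number from compound 1 to compound 2 (0.06 log units; within the scatter), whereas taking the aromatic ring away does not. Compound 3 is reported only as a limit and not as a number: the limit of > 1000 nM in this assay, at which 1 of the 3 values shown sits.

These compounds do not separate the loss of the aromatic ring from the loss of its size, so a cyclohexylmethyl group at this place remains an open case. Also open, as far as these compounds go, are what a phenethyl or a pyridylmethyl group would give, and how far compound 3 lies past its limit.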